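Propyl to Butyl Ester on a Shared Core

A few compounds are considered here, and "the series" means these few. Any claim that something is new, unique, unknown or untested is made for them only; others in the source may bear on it.

Among the measured compounds shown here, compound 2 `CCCCc1nc(C(C)C)c(CC(=O)OCCC)c(=O)n1Cc1ccc(-c2ccccc2-c2noc(=O)[nH]2)cc1` holds the only number seen here: in an ADME assay on microsomes from liver (Mus musculus) for metabolic stability, with a stated time of 30 min (on this read-out lower numbers stand for a less stable compound and higher numbers for a more stable compound), compound 2 gives 12.6%. Compound 1 `CCCCc1nc(C(C)C)c(CC(=O)OCC(F)(F)F)c(=O)n1Cc1ccc(-c2ccccc2-c2noc(=O)[nH]2)cc1` has no result reported in this assay, where compound 1 stands as "not determined" (no result reported). Compound 3 `CCCCOC(=O)Cc1c(C(C)C)nc(CCCC)n(Cc2ccc(-c3ccccc3-c3noc(=O)[nH]3)cc2)c1=O` differs from compound 2 by methyl in place of hydrogen on a saturated chain carbon, three bonds along the chain from an oxygen next to a carbonyl group. For the measured compounds named here, no step between two measured compounds exists to set a scale for this change. The expected step of a number 1.6 percentage points lower from compound 2 to compound 3 (within the scatter) lies within the usual scatter of such measurements. Compound 3 is therefore estimated at 11%, within a range from 4% to 25%.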

Compound 3, percent of the compound remaining: 21.6%
Estimate against measurement, compound 3: 10.6 percentage points below; low and high end bracket the measured number.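

In this assay, methyl in place of hydrogen on a saturated chain carbon, three bonds along the chain from an oxygen next to a carbonyl group, gives a number 9 percentage points higher from compound 2 to compound 3 (within the scatter) and so does not separate the propyl ester from the butyl ester. This is the only scale so far for a change at this position. No measured evidence here offers a reason for the result. Going by these compounds, whether a pentyl ester, or a carboxylic acid in place of the ester, would move the read-out beyond the scatter stays open.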